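Moving the Hydroxyl Group Weakens Cytotoxicity Toward Skin Cells

This account rests on a few compounds, and the source may have more. Where it says the series, first, only, none or still open, it means among the compounds named here.

Compound 1 `COc1cccc(/C=C2\CCC/C(=C\c3cccc(O)c3)C2=O)c1OC` and compound 2 `COc1cccc(/C=C2\CCC/C(=C\c3ccc(O)cc3)C2=O)c1OC` share one core and differ only in the hydroxyphenyl attached to it. In an ADME assay on NHDF cells (Homo sapiens) for cytotoxicity, read by MTT assay, with a stated time of 72 h (on this read-out lower numbers stand for stronger inhibition and higher numbers for weaker inhibition), compound 1 gives 19300 nM. Compound 2 reaches only a limit in this assay, > 50000 nM, which is a boundary of the test rather than a number (the limit of > 50000 nM in this assay, at which 1 of the 3 values shown sits). The change between them is 4-hydroxyphenyl in place of 3-hydroxyphenyl on a double-bonded chain carbon bound to a double-bonded ring carbon and it produced an at least 2.5-fold higher number from compound 1 to compound 2 (0.41 log units; beyond the scatter). Compound 3 `COc1ccc(/C=C2\CCC/C(=C\c3cccc(O)c3)C2=O)cc1OC` rests on another core; how the cores of compound 1 and compound 3 differ is not broken down here. In this assay compound 3 gives 6800 nM, the lowest number shown, with compound 1 the nearest. Compound 4 `COc1ccc(/C=C2\CCC/C(=C\c3ccc(O)cc3)C2=O)cc1OC` is not yet measured and carries the same change as before, (4-hydroxyphenyl in place of 3-hydroxyphenyl on a double-bonded chain carbon bound to a double-bonded ring carbon). Because that change earlier gave an at least 2.5-fold higher number from compound 1 to compound 2 (0.41 log units; beyond the scatter), the expected step here is a 3.2-fold higher number from compound 3 to compound 4 (0.51 log units; beyond the scatter). Compound 4 is therefore expected to give about 22000 nM, somewhere from 9000 nM to 60000 nM.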

Compound 4, half-maximal inhibitory concentration: 26100 nM
Beside the measured number, compound 4's estimate is 1.2-fold (0.07 log units) below it; the range from low to high includes it.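

Putting 4-hydroxyphenyl in place of 3-hydroxyphenyl gives a 3.8-fold higher number from compound 3 to compound 4 (0.58 log units; beyond the scatter) in this assay, so the change moves the number the same way on both cores shown: the same change on two cores in this assay, an at least 2.5-fold higher number (0.41 log units; beyond the scatter) from compound 1 to compound 2 and a 3.8-fold higher number (0.58 log units; beyond the scatter) from compound 3 to compound 4; the limit leaves it open whether they differ Compound 2 stands at a limit of the assay, > 50000 nM, and not at a number. The direction of the change therefore carries over between these two cores, but whether its size stays the same cannot be read, and two cores cannot speak for the whole series.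

The compounds shown leave open whether an amine or a carboxylic acid in place of the hydroxyl would move the number the same way. From the compounds shown here alone, whether the step holds on a third core also remains open.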